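This account rests on a few compounds, and the source may have more. Where it says the series, first, only, none or still open, it means among the compounds named here.

In a functional assay on HCT-116 cells (Homo sapiens) for antiproliferative activity, read by MTT assay, with a stated time of 24 h (on this read-out higher numbers stand for weaker inhibition and lower numbers for stronger inhibition), compound 1 (`COc1ccc(C(=O)/C=C/c2ccc(F)cc2)c2c1C=CC(C)(C)O2`) gives > 10000 nM as a limit and not a number. Compound 2 (`COc1ccc(C(=O)/C=C/c2ccc(Br)cc2)c2c1C=CC(C)(C)O2`) gives > 10000 nM as a limit as well. Compound 3 (`COc1ccc(C(=O)/C=C/c2ccc(-c3ccccc3)cc2)c2c1C=CC(C)(C)O2`) likewise stands only at a limit, with > 10000 nM as its reading. All three sit at one ceiling (the limit of > 10000 nM in this assay, at which 3 of the 3 values shown sit). Compound 4 (`CCN(CC)c1ccc(/C=C/C(=O)c2ccc(OC)c3c2OC(C)(C)C=C3)cc1`) differs from compound 3 in one group (diethylamino in place of phenyl on an aromatic carbon), para to a large group. The measured steps (a step that the two limits leave unreadable from compound 1 to compound 2 and a step that the two limits leave unreadable from compound 1 to compound 3 and a step that the two limits leave unreadable from compound 2 to compound 3) have no readable size, so they suggest no direction in this assay. An estimated step (an at least 1.1-fold lower number from compound 3 to compound 4 (0.04 log units; that floor lies within the scatter)) near the limit is therefore expected. The estimate for compound 4 is 9000 nM within an expected range (2000 nM to 30000 nM).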

Compound 4, half-maximal inhibitory concentration: 620 nM
Compound 4: the middle estimate sits 15-fold (1.16 log units) above what was measured; measured number outside the range, below it.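

In this assay diethylamino on this aromatic carbon, para to a large group, brings the series off its ceiling, with an at least 16-fold lower number from compound 3 to compound 4 (1.20 log units; beyond the scatter) against phenyl, an at least 16-fold lower number from compound 2 to compound 4 (1.20 log units; beyond the scatter) against bromo and an at least 16-fold lower number from compound 1 to compound 4 (1.20 log units; beyond the scatter) against fluoro. Each of these sizes is a floor, since the far end of each step is a limit. The steps among compound 1, compound 2 and compound 3 cannot be read, as all three rest on one limit: the limit of > 10000 nM in this assay, at which 3 of the 4 values shown sit.

Open: whether dimethylamino, a primary amine or methoxy on this carbon would keep the step, and whether it rests on the nitrogen or on the ethyl chains.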